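A few compounds are considered here, and "the series" means these few. Any claim that something is new, unique, unknown or untested is made for them only; others in the source may bear on it.

Measured so far in an ADME assay on MDCK cells (Canis lupus familiaris) for cytotoxicity, read by microscopy, with a stated time of 48 h; a lower number here means that less compound is tolerated, a higher number that more compound is tolerated:
Compound 1 `C[C@H]1[C@H](NCc2cccs2)C[C@H]2C[C@@H]1C2(C)C` gives 25000 nM.
Compound 2 `C[C@H]1[C@H](NCc2sccc2Br)C[C@H]2C[C@@H]1C2(C)C` gives 50000 nM.

Compound 2 stands at the highest of the two numbers in this assay; the nearest is compound 1, and the step of a 2.0-fold higher number from compound 1 to compound 2 (0.30 log units; within the scatter) lies within the scatter, so the two compounds cannot be told apart on these numbers. Compound 3 `CCOc1ccsc1CN[C@@H]1C[C@H]2C[C@@H]([C@H]1C)C2(C)C` has not yet been measured. It differs from compound 2 in one place: ethoxy in place of bromo on an aromatic carbon.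

For the measured compounds named here, only one measured step exists, a 2.0-fold higher number from compound 1 to compound 2 (0.30 log units; within the scatter), and it concerns bromo in place of hydrogen, not ethoxy in place of bromo. Going by the values given here, no step for ethoxy has been measured, so there is nothing to suggest a change beyond the scatter in either direction; the one step available was itself within the scatter. The expectation for compound 3 is therefore a number close to that of compound 2, with the step of a 1.3-fold lower number from compound 2 to compound 3 (0.10 log units; within the scatter) expected to stay within the scatter. Compound 3 is estimated at 40000 nM, in the range 15000 nM to 100000 nM.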

Compound 3, minimum cytotoxic concentration: 50000 nM
The estimate for compound 3 lay 1.3-fold (0.10 log units) below the measured number; the range from low to high includes it.
By their numbers in this assay, from the lowest: compounds 1, 2 and 3 (each within the scatter of the next).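

In this assay, this ring carbon, next to the ring atom that bears a large group and two ring bonds from the ring sulfur, has now carried hydrogen, bromo and ethoxy, and all three readings lie within the scatter of one another. Replacing bromo with ethoxy swaps one heavy atom for three and adds a hydrogen-bond acceptor, yet it gives no change at the digits printed from compound 2 to compound 3 (within the scatter), while ethoxy in place of hydrogen gives a 2.0-fold higher number from compound 1 to compound 3 (0.30 log units; within the scatter), so two quite different groups have now been placed here with no difference that can be told from the scatter. Nothing measured here offers an explanation for this result.

Going by these compounds, whether the same holds for groups of another kind, such as an amine or a carboxylic acid, or for a longer chain such as butoxy, remains open. Also open, on these data alone, is whether ethoxy at another carbon of this ring, or any other change to the shared core, can move the number in this assay beyond the scatter.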